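Swapping allyl for pyridin-3-yl on a thiosemicarbazone nitrogen

The compounds below may be only part of what the source reports. "The series", "measured", "known", "first", "only" and "open" are said of these compounds alone.

Compound 1, `C=CCNC(=S)N/N=C\c1ccnc2ccccc12`: 1230 nM in a functional assay on T47D cells (Homo sapiens) for cytotoxicity, read by MTT assay, with a stated time of 48 h; on this read-out higher numbers stand for weaker inhibition and lower numbers for stronger inhibition
Compound 2, `O=[N+]([O-])c1ccc(NC(=S)N/N=C\c2ccnc3ccccc23)cc1`: 1330 nM in this assay

Compound 1 holds the lower of the two numbers, yet compound 2 sits within the scatter of it, so the two cannot be told apart. Compound 3, `S=C(N/N=C\c1ccnc2ccccc12)Nc1cccnc1`, awaits measurement in this assay. It differs from compound 1 by pyridin-3-yl in place of allyl on an amide-type nitrogen. Among the compounds with values here, no step between measured compounds is known here; because compound 2 gives 1330 nM, the change is expected to bring no step beyond the scatter: a 1.1-fold higher number from compound 1 to compound 3 (0.02 log units; within the scatter). Compound 3 is therefore estimated at 1300 nM, expected between 500 nM and 3500 nM.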

Compound 3, half-maximal inhibitory concentration: 1100 nM
Compound 3: the middle estimate sits 1.2-fold (0.07 log units) above what was measured; the measured number falls inside the stated range.
By their numbers in this assay, from the lowest: compounds 3, 1 and 2 (each within the scatter of the next).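

In this assay the swap from allyl to pyridin-3-yl on the amide-type nitrogen gives a 1.1-fold lower number from compound 1 to compound 3 (0.05 log units; within the scatter) and so shows that this position tolerates a six-membered aromatic ring with a hetero atom as well as an open chain. The assay cannot separate the two groups, though pyridin-3-yl brings more heavy atoms and a hydrogen-bond acceptor. Nothing available gives a reason for this result. Still open, as far as these compounds go, is whether a longer chain such as hexyl, or a ring bearing a carboxylic acid, would fit here equally well. Pyridin-4-yl leaves open whether the place of the ring nitrogen matters.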